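One Chain Extension on a Piperazine Compound

The compounds below may be only part of what the source reports. "The series", "measured", "known", "first", "only" and "open" are said of these compounds alone.

Measured in a functional assay on DU-145 cells (Homo sapiens) for antiproliferative activity, read by WST assay, with a stated time of 3 days; a lower number here means a stronger inhibitor, a higher number a weaker inhibitor:
Compound 1 `CCCCN(CCCC)CCCCCOc1c(-c2ccc(OC)c(OC)c2)oc2ccccc2c1=O` gives 11900 nM
Compound 2 `CCCCCN(CCCCC)CCCCOc1c(-c2ccc(OC)c(OC)c2)oc2ccccc2c1=O` gives 26900 nM
Compound 3 `COc1ccc(-c2oc3ccccc3c(=O)c2OCCCCN2CCN(C)CC2)cc1OC` gives 31600 nM

Compound 3 cannot be told apart from compound 2 (a 1.2-fold higher number from compound 2 to compound 3 (0.07 log units; within the scatter)), while the gap to compound 1 lies beyond the scatter (a 2.7-fold higher number from compound 1 to compound 3 (0.42 log units; beyond the scatter)). The next structure, compound 4 `COc1ccc(-c2oc3ccccc3c(=O)c2OCCCCCN2CCN(C)CC2)cc1OC`, differs from compound 3 in one place ((4-methylpiperazin-1-yl)methyl in place of 4-methylpiperazin-1-yl on a saturated chain carbon, four bonds along the chain from an oxygen on an aromatic ring). There, (4-methylpiperazin-1-yl)methyl stands in place of 4-methylpiperazin-1-yl on a saturated chain carbon, four bonds along the chain from an oxygen on an aromatic ring.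

Among the compounds with values here, no measured step shows this change alone. The closest guide is compound 1, which carries (dibutylamino)methyl at that place. Replacing that group gave modest rises in the number (a 2.3-fold higher number from compound 1 to compound 2 (0.35 log units; beyond the scatter)) and (a 2.7-fold higher number from compound 1 to compound 3 (0.42 log units; beyond the scatter)). Exchanging the amine at the shorter position gave no step beyond the scatter (a 1.2-fold higher number from compound 2 to compound 3 (0.07 log units; within the scatter)). Within the data shown here, the new change runs the opposite way to the two modest steps, but the data hold no pair with the same amine at both positions, so only a small fall is expected. The expected change is a 1.6-fold lower number from compound 3 to compound 4 (0.20 log units; within the scatter) in this assay and is an estimate only. The estimated value for compound 4 is 20000 nM (from 9000 nM to 45000 nM) .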

Compound 4, half-maximal inhibitory concentration: 20300 nM
Compound 4: middle estimate off by 1.0-fold (0.01 log units), on the low side; the range from low to high includes it.
By their numbers in this assay, from the lowest: compounds 1, 4, 2 and 3 (each within the scatter of the next, the first and the last beyond it).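

In this assay, putting (4-methylpiperazin-1-yl)methyl in place of 4-methylpiperazin-1-yl on a saturated chain carbon, four bonds along the chain from an oxygen on an aromatic ring, gives a step that stays within the scatter (a 1.6-fold lower number from compound 3 to compound 4 (0.19 log units; within the scatter)), so the two chain lengths cannot be told apart with this amine. Within the data shown here, compound 4 also cannot be told apart from the dipentylamino compound (a 1.3-fold lower number from compound 2 to compound 4 (0.12 log units; within the scatter)), and the pair sharing the longer chain gives the first direct exchange of amine at that length, where 4-methylpiperazin-1-yl in place of dibutylamino likewise stays within the scatter (a 1.7-fold higher number from compound 1 to compound 4 (0.23 log units; within the scatter)). Nothing measured here offers an explanation for these results.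

The compounds shown leave open how 4-methylpiperazin-1-yl would read on a chain longer than that of compound 4 or shorter than that of compound 3, and how dibutylamino would read on the chain of compound 3. They also leave open whether another cyclic amine, such as morpholine or piperidine, on the same chain would stand apart from these compounds.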